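This account rests on a few compounds, and the source may have more. Where it says the series, first, only, none or still open, it means among the compounds named here.

Of the compounds shown here, two with a shared core have been measured so far. Compound 1 `CCCCCNc1nc(N)nc2ccccc12` gives 0.1 uM in an ADME assay on HEK293 cells for agonist activity at Toll-like receptor 8 (Homo sapiens), read by a luciferase reporter, with a stated time of 6 h; on this read-out lower numbers stand for an effect already at smaller amounts and higher numbers for an effect only at larger amounts of compound. Compound 2 `CCCCNc1nc(N)nc2cccc(C)c12` gives 0.3 uM in this assay, which is the highest of the two numbers; the nearest number is that of compound 1, and the gap between the two lies beyond the usual scatter. Compound 3 `CCCCNc1nc(N)nc2cccc(OCc3ccccc3)c12` has not yet been measured. It differs from compound 2 in one place: benzyloxy in place of methyl on an aromatic carbon. Among the measured compounds shown here, no pair of measured compounds shows a change of this kind, and the single difference between compound 1 and compound 2 concerns other parts of the molecule, so it offers no guide to a benzyloxy in place of methyl on an aromatic carbon. The expected step is no change at the digits printed from compound 2 to compound 3 (within the scatter), none beyond the scatter. Compound 3 is therefore estimated to give about 0.3 uM, with a likely range from 0.06 uM to 1.5 uM.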

Compound 3, minimum effective concentration: 1.66 uM
Estimate against measurement, compound 3: 5.5-fold (0.74 log units) below, outside the stated range (above it).
By their numbers in this assay, from the lowest: compound 1; then compound 2; then compound 3.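

In this assay, putting benzyloxy in place of methyl on this aromatic carbon gives a 5.5-fold higher number from compound 2 to compound 3 (0.74 log units; beyond the scatter), so a larger amount of compound is needed before an effect appears. This shows that the position is not indifferent to what it carries, although a group with its own six-membered aromatic ring still leaves a measurable effect. Nothing available shows which part of the change, the oxygen or the added ring, accounts for the rise.

On these data alone, it remains open whether a smaller group on this carbon, such as methoxy or hydroxyl, would stay closer to compound 2, or whether the rise continues with a longer chain ending in a phenyl ring. Also open, as far as these compounds go, is whether an amine on this carbon would behave differently from either methyl or benzyloxy.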